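Chloro in Place of Methylcarbamoyl on the Shared Core

This account rests on a few compounds, and the source may have more. Where it says the series, first, only, none or still open, it means among the compounds named here.

Compound 3 `CNC(=O)c1cnc(C(=O)CCCCCCc2ccccc2)o1` gives 7 nM in an assay (Rattus norvegicus) for inhibition of Fatty-acid amide hydrolase 1 (Homo sapiens) (a higher number here means a weaker inhibitor, a lower number a stronger inhibitor), the highest of the three numbers. Compound 2 `O=C(CCCCCCc1ccccc1)c1ncc(-c2ncccn2)o1` gives 5.3 nM, and a 1.3-fold higher number from compound 2 to compound 3 (0.12 log units; within the scatter). Compound 1 `NC(=O)c1ccc(-c2cnc(C(=O)CCCCCCc3ccccc3)o2)nc1` gives 1.2 nM; a 5.8-fold higher number from compound 1 to compound 3 (0.77 log units; beyond the scatter) and a 4.4-fold higher number from compound 1 to compound 2 (0.65 log units; beyond the scatter). Compound 4 `O=C(CCCCCCc1ccccc1)c1ncc(Cl)o1` differs from compound 3 by chloro in place of methylcarbamoyl on an aromatic carbon. Within the data shown here, no measured step involves chloro, so the bearing of the earlier steps is indirect: swapping one group for another on this ring position has so far moved this assay modestly or not beyond the scatter. Compound 4 is therefore expected to show at most a modest rise, a 2.1-fold higher number from compound 3 to compound 4 (0.33 log units; beyond the scatter). The estimate for compound 4 is 15 nM, with a range from 4 nM to 60 nM.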

Compound 4, inhibition constant: 5 nM
For compound 4 the middle estimate is 3.0-fold (0.48 log units) above the measured one; the range from low to high includes it.
By their numbers in this assay, from the lowest: compound 1; then compounds 4, 2 and 3 (each within the scatter of the next).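

A single chlorine atom on the aromatic carbon next to the ring oxygen matches the much larger methylcarbamoyl in this assay (a 1.4-fold lower number from compound 3 to compound 4 (0.15 log units; within the scatter)). It also matches pyrimidin-2-yl (a 1.1-fold lower number from compound 2 to compound 4 (0.03 log units; within the scatter)). So neither a hydrogen-bond donor nor a second ring on this carbon is required to reach this level, and among these compounds only the 5-carbamoylpyridin-2-yl group stands apart (a 4.2-fold higher number from compound 1 to compound 4 (0.62 log units; beyond the scatter)).

Nothing shown gives a reason for this match. As far as these compounds go, how an amine or a carboxylic acid on this carbon would read in this assay remains open.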